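The source may hold more compounds than are shown below. What is called first, only, known or untested is meant among the compounds shown, and "the series" means these compounds.

Compound 1 `C[N+]1(CC2CCCCC2)CCc2c(sc(NC(=O)Nc3ccc(Cl)cc3)c2C(N)=O)C1`: 100 nM
Compound 2 `NC(=O)c1c(NC(=O)Nc2ccc(Cl)cc2)sc2c1CCN(CC1CCCCC1)C2`: 1890 nM

In a functional assay (strain AB) with Danio rerio as the target, read by microscopy, with a stated time of 1 h (a lower number here means that less compound is needed, a higher number that more compound is needed for the effect), compound 1 gives 100 nM. Compound 2 gives 1890 nM, the higher of the two numbers, and the gap to compound 1 lies beyond the usual scatter. Within the data shown here, no step between these two compounds changing a single place has been measured, so their numbers can only be set side by side. Compound 3 `CC(C)CN1CCc2c(sc(NC(=O)Nc3ccc(Cl)cc3)c2C(N)=O)C1` differs from compound 2 in one place: isopropyl in place of cyclohexyl on a saturated chain carbon bound to an amine nitrogen in a ring. With nothing measured for this kind of change, compound 3 is expected to stay close to compound 2, with at most a small step toward a higher number, estimated as a 1.6-fold higher number from compound 2 to compound 3 (0.20 log units; within the scatter). The estimate for compound 3 is 3000 nM, with a range from 1000 nM to 10000 nM.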

Compound 3, half-maximal effective concentration: 4510 nM
Compound 3: middle estimate off by 1.5-fold (0.18 log units), on the low side; the measured number falls inside the stated range.
By their numbers in this assay, from the lowest: compound 1; then compound 2; then compound 3.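

In this assay, among these compounds, isopropyl in place of cyclohexyl on a saturated chain carbon bound to an amine nitrogen in a ring gives a 2.4-fold higher number from compound 2 to compound 3 (0.38 log units; beyond the scatter) as the first readable step at this position. The step is modest but beyond the usual scatter, so the number here does respond to the group at this position. No measurement at hand explains the step.

On these data alone, whether a phenyl ring or a longer chain in this place would give a lower or higher number stays open. So does whether the same change would give a similar step on compound 1.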